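Unbound fraction on swapping the amide nitrogen group

This account rests on a few compounds, and the source may have more. Where it says the series, first, only, none or still open, it means among the compounds named here.

Measured so far:
- compound 1 `CNC(=O)c1cc(C(=O)N[C@H]2[C@@H]3C[C@H](O)C[C@@H]32)n([C@@H](C)c2cccc(Cl)c2)n1`: "not determined" (no result reported)
- compound 2 `CNC(=O)c1cc(C(=O)N[C@H]2[C@@H]3COC[C@@H]32)c([C@@H](C)c2ccccc2)o1`: 0.26

Going by the values given here, in an ADME assay on blood (Homo sapiens) for protein binding, read by LC-MS, using equilibrium dialysis (a higher number here means a larger unbound share of the compound, a lower number a smaller unbound share), compound 2 gives 0.26 as the only number so far. Compound 1 has no result, so it offers no comparison.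

Compound 3 `CNC(=O)c1cc(C(=O)N[C@H]2CC[C@H](O)CC2)c([C@@H](C)c2ccccc2)o1` differs from compound 2 in one place (a group of 7 heavy atoms (6 carbon, 1 oxygen; one six-membered non-aromatic ring of carbon only) in place of a group of 6 heavy atoms (5 carbon, 1 oxygen; one three-membered non-aromatic ring of carbon only, one five-membered non-aromatic ring with 1 hetero atom), on an amide-type nitrogen), where a 4-hydroxycyclohexyl group enters on the amide-type nitrogen. Among the compounds with values here, no measured step covers a change of this kind, so the sole anchor is compound 2 at 0.26 and no shift beyond the scatter is expected in this assay for this swap. The estimated step of a 1.2-fold lower number from compound 2 to compound 3 (0.07 log units; within the scatter) stays within the usual scatter of such measurements, with no direction expected. For compound 3 the estimate is 0.22 with an expected range from 0.12 to 0.38 as unbound fraction.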

Compound 3, unbound fraction in the Homo sapiens assay: 0.33
For compound 3 the middle estimate is 1.5-fold (0.18 log units) below the measured one; the measured number falls inside the stated range.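

In the Homo sapiens assay, replacing the group on the amide-type nitrogen with 4-hydroxycyclohexyl gives a 1.3-fold higher number from compound 2 to compound 3 (0.10 log units; within the scatter), so this change leaves the unbound fraction within the scatter. In a physicochemical assay for lipophilicity (a lower number here means a more polar compound, a higher number a more lipophilic compound), compound 2 gives 4.1 and compound 3 gives 2.8 as measured values. In the physicochemical assay, the same change gives a step of a different size: the measured distribution coefficient of compound 2, 4.1, and of compound 3, 2.8, a number 1.30 log units lower (beyond the scatter) This first readable pair at this place therefore shows a step beyond the scatter in the physicochemical assay alongside one within the scatter in the Homo sapiens assay, so in this pair the unbound fraction does not follow the distribution coefficient.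

One pair cannot show whether this separation holds for other groups on the amide-type nitrogen, such as an aminocyclohexyl or a carboxylic acid-bearing cyclohexyl. A plain cyclohexyl would be needed to separate the contribution of the hydroxyl from that of the ring, which change together here.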